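A Hydroxy Group Enters the Phenyl Ring of Compound 1

The source may hold more compounds than are shown below. What is called first, only, known or untested is meant among the compounds shown, and "the series" means these compounds.

For the measured compounds named here, compound 1 `O=C(/N=C1\NC2(CCCCO2)CCS1)c1ccccc1` is the only member of this small series with a definite number: in a functional assay on the whole organism (strain CF-1) with Mus musculus as the target, in the writhing test, with a stated time of 15 min (a lower number here means that less compound is needed, a higher number that more compound is needed for the effect), compound 1 gives 5 mg/kg. Compound 2 `O=C(/N=C1\NC2(CCCCO2)CCS1)c1cccc(C(F)(F)F)c1` carries trifluoromethyl in place of hydrogen on an aromatic carbon, and in this assay compound 2 stops at > 200 mg/kg, which is a limit of the assay and not a number. Compound 3 `O=C(/N=C1\NC2(CCCCO2)CCS1)c1cccc([N+](=O)[O-])c1`, with nitro in place of hydrogen on an aromatic carbon, likewise stops at the limit of > 200 mg/kg. The step of an at least 40-fold higher number from compound 1 to compound 2 (1.60 log units; beyond the scatter) and the step of an at least 40-fold higher number from compound 1 to compound 3 (1.60 log units; beyond the scatter) therefore both point the same way, both resting on (the limit of > 200 mg/kg in this assay, at which 2 of the 3 values shown sit). Compound 4 `O=C(/N=C1\NC2(CCCCO2)CCS1)c1ccccc1O` is not yet measured; it differs from compound 1 by hydroxy in place of hydrogen on an aromatic carbon, a smaller group than either of the two already tried, set ortho to a large group. Both earlier additions to the ring raised the dose needed by a large margin, so an increase is expected here too, though hydroxy is a different kind of group and those two steps are all the evidence there is. Compound 4 is therefore expected to need 30 mg/kg, between 6 mg/kg and 200 mg/kg. That estimate means an expected step of a 6.0-fold higher number from compound 1 to compound 4 (0.78 log units; beyond the scatter), held with little confidence.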

Compound 4, dose for half-maximal effect: > 200 mg/kg
Compound 4 was reported as a limit; the forecaster's own chance of this, stated with the estimate: 30%; at least 6.6-fold (0.82 log units) between middle value and limit.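

In this assay compound 4 stops at > 200 mg/kg, which is a limit of the assay and not a number. The step of an at least 40-fold higher number from compound 1 to compound 4 (1.60 log units; beyond the scatter) shows that trifluoromethyl and nitro are not the only additions that go with this large rise: hydroxy, with a single heavy atom, ortho to a large group, goes with it too, so that of the four compounds only compound 1, with its plain phenyl, gives a number. The steps among compound 2, compound 3 and compound 4 cannot be read, because all three values are the same limit: the limit of > 200 mg/kg in this assay, at which 3 of the 4 values shown sit.

Going by these compounds, whether fluorine, methyl or an amine on this same carbon would give a number remains open. So does whether hydroxy on another carbon of the ring would give one.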